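The source may hold more compounds than are shown below. What is called first, only, known or untested is meant among the compounds shown, and "the series" means these compounds.

Measured so far in an ADME assay on microsomes from liver (Homo sapiens) for metabolic stability, with a stated time of 30 min; on this read-out higher numbers stand for a more stable compound and lower numbers for a less stable compound:

- compound 1 `CC(C)(C)[C@@H](CO)n1cc(C(=O)O)c(=O)c2cc(Cc3cccc(Cl)c3F)c(O)nc21`: 87%
- compound 2 `CC(C)Oc1nc2c(cc1Cc1cccc(Cl)c1F)c(=O)c(C(=O)O)cn2[C@H](CO)C(C)(C)C`: "not determined" (no result reported)

For the measured compounds named here, the series offers a single number so far. Compound 1 gives 87%, a figure that anchors everything that follows. Compound 2 stands nowhere on the scale, since for compound 2 the entry reads "not determined" (no result reported). No result exists for it, so it cannot be ranked against compound 1.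

The next compound to be tested is compound 3 `CC(C)(C)[C@@H](CO)n1cc(C(=O)O)c(=O)c2cc(Cc3cccc(Cl)c3F)c(OCCO)nc21`. Its structural change is 2-hydroxyethyl in place of isopropyl on an oxygen on an aromatic ring. The rest of the molecule stays the same.

Going by the values given here, no measured step shows what such a swap does in this assay, and the missing starting value means this step cannot be sized directly. The expectation is therefore loose: a result in the same upper region as compound 1 at 87%, perhaps somewhat lower, with no firm direction. In this assay the expected value for compound 3 is 80%, with an estimated range of 55% to 97%.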

Compound 3, percent of the compound remaining: 45%
The estimate for compound 3 lay 35 percentage points above the measured number; the whole stated range lies above it.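

Putting 2-hydroxyethyl in place of hydrogen on the oxygen on an aromatic ring gives, in this assay, a number 42 percentage points lower from compound 1 to compound 3 (beyond the scatter). For the compounds shown here, this is the first readable change, and it shows that the read-out responds strongly to what sits on this oxygen, even though the rest of the molecule stays the same. The swap from isopropyl to 2-hydroxyethyl cannot be read, as compound 2 has no result, and nothing available explains the drop seen with compound 3.

The compounds shown leave open whether any group on this oxygen would bring a similar fall or whether it belongs to 2-hydroxyethyl in particular, and where isopropyl would stand on the same scale. A small methyl or a 2-methoxyethyl chain on the same oxygen would help separate these possibilities, since each would show how the read-out behaves with a different group in that place.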